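Solubility across the series: configuration change at one centre

The source may hold more compounds than are shown below. What is called first, only, known or untested is meant among the compounds shown, and "the series" means these compounds.

Three compounds of this series have numbers in a physicochemical assay for solubility, measured as kinetic solubility; a lower number here means a less soluble compound, a higher number a more soluble compound. Compound 1 `COC(c1cc(Cl)c2c(c1Cl)C(=O)N(Cc1c(C)cc(C)[nH]c1=O)CC2)C1CCN(C(C)=O)CC1` gives 532000 nM; 498000 nM (2 entries), the two entries agreeing closely (the several entries of compound 1 in this assay, 532000 nM; 498000 nM (2 entries)). Compound 2 `COc1cc(C)[nH]c(=O)c1CN1CCc2c(Cl)cc([C@@H](O)C3COC3)c(Cl)c2C1=O` gives 582000 nM, the highest of the two single numbers shown, and compound 3 `Cc1cc(C)c(CN2CCc3c(Cl)cc([C@@H](CO)[C@H]4CCCO4)c(Cl)c3C2=O)c(=O)[nH]1` gives 576000 nM, which sits within the scatter of compound 2, so no order can be read between them. Compound 1 has no single number and is only compared by its two entries, which lie close to the other two. Within the data shown here, no pair of these measured compounds differs in a single place, so no measured step exists to anchor a comparison.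

Compound 4 `COc1cc(C)[nH]c(=O)c1CN1CCc2c(Cl)cc([C@H](O)C3COC3)c(Cl)c2C1=O` is the compound to be measured. Relative to compound 2 the change is the two compounds have the same atoms and bonds and differ only in configuration as drawn: 1 of 1 stereo elements differ; a stereocentre at a saturated chain carbon is drawn S in compound 2 and R in compound 4. No evidence in the set speaks to what such a change does in this assay, and the three measured compounds all fall in a narrow band. The step from compound 2 to compound 4 is therefore expected to be no larger than the scatter, in either direction, as a 1.0-fold lower number from compound 2 to compound 4 (0.00 log units; within the scatter). Compound 4 is accordingly expected to give about 580000 nM, with a range from 400000 nM to 820000 nM.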

Compound 4, solubility: 234000 nM
Compound 4: the middle estimate sits 2.5-fold (0.39 log units) above what was measured; the measured number lies below the stated range.
By their numbers in this assay, from the lowest: compound 4; then compounds 3 and 2 (each within the scatter of the next).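

Among these compounds, the first measured step in this assay is a 2.5-fold lower number from compound 2 to compound 4 (0.40 log units; beyond the scatter), a modest step with the S configuration as drawn on the higher side. The step can be assigned to the stereocentre at the saturated chain carbon alone, with leaving and entering groups ruled out, because of one plain observation: the fact that compounds 2 and 4 differ only in the configuration as drawn. The earlier compounds shown here gave no such reading, since no two of them differ in one place and their close numbers said nothing about this stereocentre, whereas this single pair shows that configuration there is not silent in this read-out.

Going by these compounds, the result rests on one pair, so it remains open whether the same inversion gives a step of similar size or direction on other members, including those carrying the methyl group in place of the methoxy group on the shared core. On these data alone, it also remains open how this stereocentre reads in this assay when it carries a different substituent, such as an amine or a carboxylic acid.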